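Replacing the Vinyl Chain on the Core of Compound 3

The source may report more compounds than this note shows. Statements on the series, on what has been measured and on what is new or still open speak of the compounds shown alone.

Compound 1, `Nc1nc2ccc(C3CCCCC3)cc2s1`: > 10 mg/kg
Compound 2, `CC(C)c1ccc2nc(N)sc2c1`: > 10 mg/kg
Compound 3, `C=CCn1c(=N)sc2cc(OC(F)(F)F)ccc21`: 7 mg/kg

In a functional assay on the whole organism with Rattus norvegicus as the target (a lower number here means that less compound is needed, a higher number that more compound is needed for the effect), compound 1 gives > 10 mg/kg, which is a limit of the assay and not a number. Compound 2 likewise gives > 10 mg/kg, also a limit. Among the measured compounds shown here, compound 3 gives 7 mg/kg and is therefore the only compound with a number; the two others sit at the limit of > 10 mg/kg in this assay, at which 2 of the 3 values shown sit. Compound 4, `C[S+]([O-])CCCn1c(=N)sc2cc(OC(F)(F)F)ccc21`, differs from compound 3 in one place: a group of 5 heavy atoms (3 carbon, 1 oxygen, 1 sulfur; no ring) in place of a group of 2 heavy atoms (2 carbon; no ring), on a saturated chain carbon bound to an aromatic nitrogen. No pair of measured compounds shows what such a change does, so no direction can be read from the data shown. The step of a 1.1-fold higher number from compound 3 to compound 4 (0.06 log units; within the scatter) is expected to be small, within the usual scatter, in either direction. Compound 4 is accordingly estimated at 8 mg/kg, with a range from 3 mg/kg to 25 mg/kg.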

Compound 4, dose for half-maximal effect: 2.3 mg/kg
Compound 4: the middle estimate sits 3.5-fold (0.54 log units) above what was measured; the measured number lies below the stated range.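

In this assay, the change gives a 3.0-fold lower number from compound 3 to compound 4 (0.48 log units; beyond the scatter). Among the compounds shown here, this is the first measured change on a saturated chain carbon bound to an aromatic nitrogen, and it shows that the vinyl can give way to a larger, ring-free group while less compound is needed. Nothing measured here explains this step.

Whether the sulfur and oxygen or simply the added chain carbons account for the step stays open. As far as these compounds go, how an amine, a carboxylic acid or a longer chain would compare in this place also stays open.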